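Adenosine analogues with varied benzylamine aryl groups: HL-60 series

The source may hold more compounds than are shown below. What is called first, only, known or untested is meant among the compounds shown, and "the series" means these compounds.

Measured compounds:
compound 1, `OC[C@H]1O[C@@H](n2cnc3c(NCc4ccccc4F)ncnc32)[C@H](O)[C@@H]1O` — 3200 nM
compound 2, `OC[C@H]1O[C@@H](n2cnc3c(NCc4cccc(Br)c4)ncnc32)[C@H](O)[C@@H]1O` — 8000 nM

Compound 2 gives the highest number of the two in a functional assay on HL-60 cells (Homo sapiens) for antiproliferative activity, with a stated time of 72 h; a lower number here means a stronger inhibitor, a higher number a weaker inhibitor; its nearest neighbour is compound 1, and the step of a 2.5-fold higher number from compound 1 to compound 2 (0.40 log units; beyond the scatter) lies beyond the scatter. The shared core is unchanged across the series and only the aryl group on the saturated chain carbon bound to a nitrogen on an aromatic ring varies.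

Compound 3, `COc1cccc(CNc2ncnc3c2ncn3[C@@H]2O[C@H](CO)[C@@H](O)[C@H]2O)c1OC`, is not yet measured. Its difference from compound 2 is 2,3-dimethoxyphenyl in place of 3-bromophenyl on a saturated chain carbon bound to a nitrogen on an aromatic ring. Among the compounds with values here, the single measured step, a 2.5-fold higher number from compound 1 to compound 2 (0.40 log units; beyond the scatter), shows that exchanging one aryl group for another moves this assay by a modest amount. Within the data shown here, no measured step involves a methoxy group, so the direction for compound 3 is uncertain; a modest move of about the same size, or none beyond the scatter, is expected. The estimate for compound 3 in this assay is 5000 nM, within 1500 nM to 16000 nM, which would mean a step of a 1.6-fold lower number from compound 2 to compound 3 (0.20 log units; within the scatter).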

Compound 3, half-maximal inhibitory concentration: > 166000 nM
Compound 3 ended at the assay's limit; the forecaster's own chance of this, stated with the estimate: 10%; middle value at least 33-fold (1.52 log units) from the limit.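

Within the data shown here, the aryl group at this position can do far more than the single earlier step suggested: in this assay, 2,3-dimethoxyphenyl gives an at least 20-fold higher number from compound 2 to compound 3 (1.31 log units; beyond the scatter) and an at least 51-fold higher number from compound 1 to compound 3 (1.71 log units; beyond the scatter), both large beside the modest 2.5-fold higher number from compound 1 to compound 2 (0.40 log units; beyond the scatter). Compound 3 is the only one of the three without a halogen on the phenyl ring and the only one without a measurable half-maximal inhibitory concentration, though three compounds fix no rule. For compound 3, > 166000 nM is a limit of the assay and not a number, so both new steps are bounds, as the evidence shows: the limit of > 166000 nM in this assay, at which 1 of the 3 values shown sits.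

From the compounds shown here alone, how far compound 3 lies past that limit remains unknown, and the two methoxy groups cannot be separated from each other here. Going by these compounds, whether a phenyl ring with a single methoxy group, or one carrying an amine or a carboxylic acid, keeps a measurable value also stays open.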